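The source may hold more compounds than are shown below. What is called first, only, known or untested is meant among the compounds shown, and "the series" means these compounds.

In a functional assay on TK-10 cells (Homo sapiens) for inhibition, read by sulforhodamine B assay, with a stated time of 48 h (a lower number here means a stronger inhibitor of growth, a higher number a weaker inhibitor of growth), compound 1 `COc1cc(-c2nn(-c3cccc(NC(=O)c4cccc(C(F)(F)F)c4)c3)cc2-c2ccncc2)ccc1Cl` gives > 50000 nM, which is a limit and not a number. Compound 2 `COc1cc(-c2nn(-c3cccc(NC(=O)c4ccc(Cl)c(C(F)(F)F)c4)c3)cc2-c2ccncc2)ccc1Cl` gives > 32500 nM, which is also a limit. Compound 3 `O=C(Nc1cccc(-n2cc(-c3ccncc3)c(-c3ccc(Cl)c(O)c3)n2)c1)Nc1cc(C(F)(F)F)cc(C(F)(F)F)c1` differs from compound 1 in more than one place. Compound 3 gives a measured number of 3580 nM.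

Compound 4 `COc1cc(-c2nn(-c3cccc(NC(=O)c4ccccc4)c3)cc2-c2ccncc2)ccc1Cl` keeps the core of compound 1 and makes one change: hydrogen in place of trifluoromethyl on an aromatic carbon. This puts hydrogen in place of trifluoromethyl on an aromatic carbon, meta to a large group, turning 3-(trifluoromethyl)phenyl into phenyl.

Among the measured compounds shown here, the one measured step that bears on this is a step that the two limits leave unreadable from compound 1 to compound 2, which puts chloro in place of hydrogen on an aromatic carbon. Both of its ends are limits, so it offers no size to carry over. Nothing measured points to a gain, so no step beyond the scatter is expected in this assay. The expected change is a number no higher from compound 1 to compound 4 (the limit leaves the size open). Compound 4 is expected at 50000 nM, with an estimated range from 20000 nM to 100000 nM, and the assay may well report only a limit.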

Compound 4, concentration for total growth inhibition: > 100000 nM
Compound 4 was reported as a limit; the forecaster's own chance of this, stated with the estimate: 70%; middle value at least 2.0-fold (0.30 log units) away from the limit.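

Compound 1, compound 2 and compound 4 each give only a limit in this assay, and the steps among them cannot be read. The compounds shown leave open how far apart these three compounds truly lie, and whether trifluoromethyl or chloro changes growth inhibition at all.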